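Methylsulfanyl in place of methyl on the furan-bearing core

This account rests on a few compounds, and the source may have more. Where it says the series, first, only, none or still open, it means among the compounds named here.

Compound 3 `Cc1ncnc2c1c(-c1ccoc1)cn2[C@@H]1O[C@H](CO)[C@@H](O)[C@H]1O` carries a methyl on the shared core and gives 5320 nM in a functional assay on HepG2 cells (Homo sapiens) for antiproliferative activity, read by XTT assay, with a stated time of 72 h; on this read-out higher numbers stand for weaker inhibition and lower numbers for stronger inhibition; of the two numbers shown in this assay it is the higher. Compound 1 `COc1ncnc2c1c(-c1ccoc1)cn2[C@@H]1O[C@H](CO)[C@@H](O)[C@H]1O`, with methoxy in the same place, gives 290 nM in this assay, and the step of an 18-fold higher number from compound 1 to compound 3 (1.26 log units; beyond the scatter) is large. Compound 2 `CSc1ncnc2c1c(-c1ccccc1)cn2[C@@H]1O[C@H](CO)[C@@H](O)[C@H]1O`, which carries methylsulfanyl on a phenyl-bearing core, gives > 20000 nM in this assay, which is a limit of the assay and not a number, namely (the limit of > 20000 nM in this assay, at which 1 of the 3 values shown sits).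

Compound 4 `CSc1ncnc2c1c(-c1ccoc1)cn2[C@@H]1O[C@H](CO)[C@@H](O)[C@H]1O` differs from compound 3 by methylsulfanyl in place of methyl on an aromatic carbon. For the measured compounds named here, no measured step covers methyl against methylsulfanyl on this core; the only measured step at this position, from methoxy to methyl, widened the number greatly, and compound 2 shows that methylsulfanyl on the phenyl-bearing core did not give a number at all. The expectation is therefore a step of a 1.1-fold lower number from compound 3 to compound 4 (0.03 log units; within the scatter) of small size, with a real chance that compound 4 also reaches only the limit. Compound 4 is estimated at 5000 nM, between 1200 nM and 20000 nM.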

Compound 4, half-maximal inhibitory concentration: > 15000 nM
Compound 4 ended at the assay's limit; the forecaster's own chance of this, stated with the estimate: 25%; middle value at least 3.0-fold (0.47 log units) from the limit.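

In this assay, methylsulfanyl does not hold even the modest value of the methyl analogue at this position on the shared core, giving an at least 2.8-fold higher number from compound 3 to compound 4 (0.45 log units; beyond the scatter). Against methoxy at the same place, the change is large, with an at least 51-fold higher number from compound 1 to compound 4 (1.71 log units; beyond the scatter), and of the three groups compared on this core, only methoxy gives a value beyond the scatter of the others on the stronger side. Compound 4 stands at a limit of the assay, not at a number: the limit of > 15000 nM in this assay, at which 1 of the 4 values shown sits.

As far as these compounds go, compound 2 and compound 4 both carry limits and the step between them cannot be read, so furan-3-yl against phenyl stays open with methylsulfanyl in place. Also open, from the compounds shown here alone, is whether an amine or a longer chain such as ethoxy at this position would keep or improve on compound 1, at 290 nM.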